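Methyl to hydrogen on the aromatic ring of compound 1

A few compounds are considered here, and "the series" means these few. Any claim that something is new, unique, unknown or untested is made for them only; others in the source may bear on it.

Compound 1 `Cc1ccc(C2CNC(=O)N2S(=O)(=O)c2ccc3c(c2)CCC3)cc1` is the starting point. Among the compounds with values here, in a functional assay on A549 cells (Homo sapiens) for cytotoxicity (a higher number here means a weaker inhibitor, a lower number a stronger inhibitor), compound 1 gives 90300 nM, the second highest of the three numbers so far. Compound 2 `Cc1ccc(C2CN(S(=O)(=O)c3ccc4c(c3)CCC4)C(=O)N2)cc1` sits nearest: in this assay compound 2 gives 99200 nM, a difference from compound 1 that lies within the scatter, so no order between the two is claimed. Compound 3 `Cc1ccc(S(=O)(=O)N2CC(c3ccccc3)NC2=O)cc1` stands furthest away: in this assay compound 3 gives 12500 nM, a lower number than compound 1, beyond the scatter.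

Compound 4 `O=C1NCC(c2ccccc2)N1S(=O)(=O)c1ccc2c(c1)CCC2` has not been measured in this assay. It differs from compound 1 in one place: hydrogen in place of methyl on an aromatic carbon. Cut one bond further out, the change reads 4-methylphenyl to phenyl. Within the data shown here, no pair of measured compounds shows this change, so nothing says what size of step to expect. With a single carbon leaving and nothing else altered, compound 4 is expected to stay within the scatter of compound 1, a step of a 1.0-fold lower number from compound 1 to compound 4 (0.00 log units; within the scatter). Compound 4 is estimated at 90000 nM, with a range from 30000 nM to 250000 nM.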

Compound 4, half-maximal inhibitory concentration: 58500 nM
Compound 4: the middle estimate sits 1.5-fold (0.19 log units) above what was measured; low and high end bracket the measured number.
By their numbers in this assay, from the lowest: compound 3; then compounds 4, 1 and 2 (each within the scatter of the next).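

Hydrogen in place of methyl is the first one-place change readable in this series: in this assay it gives a 1.5-fold lower number from compound 1 to compound 4 (0.19 log units; within the scatter). The assay therefore does not tell methyl from hydrogen at this aromatic carbon on the core of compound 1, although this rests on a single pair. Nothing measured here offers an explanation for this result.

From the compounds shown here alone, whether a methoxy group, a chlorine atom or a carboxylic acid at the same carbon would give a step beyond the scatter remains open. Also open, going by these compounds, is whether hydrogen in place of methyl reads the same way on compound 2, which carries the same 4-methylphenyl group.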